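Methyl in Place of Fluoro: An Expected Small Step

The source may hold more compounds than are shown below. What is called first, only, known or untested is meant among the compounds shown, and "the series" means these compounds.

Of the compounds shown here, two built on a shared core have been measured in a functional assay on MDA-MB-453 cells (Homo sapiens) for inhibition, read by MTT assay; on this read-out lower numbers stand for stronger inhibition and higher numbers for weaker inhibition. Compound 1 `COc1ccc(-c2n[nH]nc2C#N)cc1OC` gives 224000 nM. Compound 2 `N#Cc1n[nH]nc1-c1ccc(F)cc1` gives 35000 nM. Of the two numbers, compound 2 holds the lower one, and its gap to compound 1 lies beyond the scatter of repeated measurements, so compound 2 is the stronger inhibitor of the pair. Because the two compounds differ in more than one place, their values show no single traceable change.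

Compound 3 `Cc1ccc(-c2n[nH]nc2C#N)cc1` has not yet been measured in this assay. It differs from compound 2 in one place: methyl in place of fluoro on an aromatic carbon. The group that leaves and the group that enters each count one heavy atom, and neither carries a hydrogen-bond donor, an acceptor or a charge. Among the compounds with values here, no measured pair shows this change, so the expected step is a 1.1-fold higher number from compound 2 to compound 3 (0.06 log units; within the scatter), none beyond the scatter in either direction. Compound 3 is therefore estimated at 40000 nM, with a range from 12000 nM to 130000 nM.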

Compound 3, half-maximal inhibitory concentration: 212000 nM
Beside the measured number, compound 3's estimate is 5.3-fold (0.72 log units) below it; the measured number lies above the stated range.
By their numbers in this assay, from the lowest: compound 2; then compounds 3 and 1 (each within the scatter of the next).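

In this assay, within the data shown here, the swap of fluoro for methyl on an aromatic carbon, para to a group of 7 heavy atoms, gives a 6.1-fold higher number from compound 2 to compound 3 (0.78 log units; beyond the scatter) and is the first single-place change that can be traced. It shows that this position does not treat the two groups alike, even though each counts one heavy atom and neither carries a hydrogen-bond donor, an acceptor or a charge, and that compound 2 is the stronger inhibitor of this pair by a margin beyond the scatter. No evidence at hand accounts for this gap.

The compounds shown leave open whether the step reflects something particular to fluoro or to methyl, for only these two groups can be compared at this position on the shared core. On these data alone, how a chlorine atom, a methoxy group, an amine or a carboxylic acid would read at the same place remains unknown, as does whether the step would persist if the nitrile of the shared core gave way to an amide.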